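The source may report more compounds than this note shows. Statements on the series, on what has been measured and on what is new or still open speak of the compounds shown alone.

Of the compounds shown here, three have been tested in a functional assay on HCT-116 cells (Homo sapiens) for antiproliferative activity, read by MTT assay, with a stated time of 48 h (on this read-out lower numbers stand for stronger inhibition and higher numbers for weaker inhibition), and a fourth awaits its turn. Compound 1 `CCCCCCCC(CCO)n1cnc2c(N)ncnc21` carries an amino group on its core and a long chain that ends in a hydroxyl. In this assay compound 1 gives > 50000 nM, which is a limit of the assay and not a number. Compound 2 `CCCCCCCC(CCO)n1cnc2c(N)nc(Cl)nc21` differs from compound 1 by chloro in place of hydrogen on an aromatic carbon. In this assay compound 2 gives > 50000 nM, again a limit rather than a number. The step that the two limits leave unreadable from compound 1 to compound 2 cannot be sized because the limit of > 50000 nM in this assay, at which 2 of the 3 values shown sit, covers both of these compounds.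

Compound 3 `CCCCCCCCC(CCO)n1cnc2c(Cl)ncnc21` has a different core from compound 1; the difference between the two cores is not broken down here. In this assay, going by the values given here, compound 3 gives 1650 nM, the only plain number among the measured compounds.

Compound 4 `CCCCCCCCC(CCO)n1cnc2c(Cl)nc(Cl)nc21` differs from compound 3 by chloro in place of hydrogen on an aromatic carbon. Among the compounds with values here, this is the same kind of change as the one from compound 1 to compound 2, though the surroundings differ: in compound 2 the chloro sits meta to an amino group, whereas in compound 4 it sits meta to a chloro group. The earlier pair offers no readable step, as both values are limits.

The value of compound 3 at 1650 nM is therefore the only anchor for the expectation. The step is expected to be about a 1.1-fold lower number from compound 3 to compound 4 (0.04 log units; within the scatter). Compound 4 is estimated at 1500 nM, most likely between 500 nM and 5000 nM.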

Compound 4, half-maximal inhibitory concentration: 22200 nM
The estimate for compound 4 lay 15-fold (1.17 log units) below the measured number; measured number outside the range, above it.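

In this assay, chloro in place of hydrogen on an aromatic carbon, between two ring nitrogen atoms, gives a 13-fold higher number from compound 3 to compound 4 (1.13 log units; beyond the scatter), so on the core of compound 3 this one small change clearly weakens inhibition. The same change on the core of compound 1 offers nothing to set beside this result, since compound 1 and compound 2 both stand at a limit of the assay and not at a number, which leaves their step unreadable: the limit of > 50000 nM in this assay, at which 2 of the 4 values shown sit. This means the large step is established for a single pair only, and it does not show whether the change acts in the same direction or to the same extent on the other core, so it cannot yet be treated as a rule for the series.

The compounds shown leave open whether the loss belongs to chloro itself or would also appear with another group on that carbon, such as fluoro, methyl, methoxy or an amine. They also leave open how the same change would behave on a core where both members of the pair give plain numbers, which is what a real comparison between cores would need.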